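Swapping a Ring for a Hydroxy on an Amide Nitrogen

The compounds below may be only part of what the source reports. "The series", "measured", "known", "first", "only" and "open" are said of these compounds alone.

Within the data shown here, compound 1 `Cc1ccc(OCC(=O)N(Cc2cccs2)C2CCCCC2)cc1` is the only compound here with a number: in an assay on HEK293 cells for agonist activity at transient receptor potential cation channel subfamily M member 8 (Homo sapiens), read by fluorescence and calcium flux, with a stated time of 15 min (a higher number here means that more compound is needed for the effect, a lower number that less compound is needed), compound 1 gives 40000 nM, so a large amount is needed for its effect. Compound 2 `Cc1ccc(OC2CCN(Cc3cccs3)C2=O)cc1` gave no number at all, reported in this assay as "not active" (no number reported). Compound 3 `Cc1ccc(OCC(=O)N(O)Cc2cccs2)cc1` differs from compound 1 in one place (hydroxy in place of cyclohexyl on an amide-type nitrogen). Among the measured compounds shown here, with no measured step of this kind available, the expected change a 1.8-fold higher number from compound 1 to compound 3 (0.24 log units; within the scatter) is a small loss beyond the scatter, and a result without a number is quite possible. Compound 3 is therefore estimated at 70000 nM, within a range from 20000 nM to 250000 nM.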

Compound 3, half-maximal effective concentration: 8000 nM
For compound 3 the middle estimate is 8.8-fold (0.94 log units) above the measured one; measured number below the stated range.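

Hydroxy in place of cyclohexyl on the amide-type nitrogen gives a 5.0-fold lower number from compound 1 to compound 3 (0.70 log units; beyond the scatter) in this assay, so less compound is needed for the effect. The ring of six carbons is therefore not required at this position, and a single oxygen-bearing group does better in its place. Why this happens cannot be said from anything available here.

Still open, as far as these compounds go, is whether the gain comes from the hydroxy itself or from the loss of cyclohexyl. A methyl or a methoxy on this same nitrogen would help separate the two.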